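Chain carboxylates on a bicyclic acid amide core

The source may report more compounds than this note shows. Statements on the series, on what has been measured and on what is new or still open speak of the compounds shown alone.

Compound 1 `CCCCNC(=O)C1C(C(=O)O)[C@@H]2CC[C@H]1O2`: 10000 nM
Compound 2 `O=C(O)CCCNC(=O)C1C(C(=O)O)[C@@H]2CC[C@H]1O2`: 10000 nM
Compound 3 `O=C(O)CCCCCCCNC(=O)C1C(C(=O)O)[C@@H]2CC[C@H]1O2`: 10000 nM

These three compounds share one core and differ only in the chain on the amide nitrogen. In an ADME assay on A2780 cells (Homo sapiens) for cytotoxicity, read by MTT assay, with a stated time of 72 h (on this read-out lower numbers stand for stronger inhibition of growth and higher numbers for weaker inhibition of growth), compound 1 gives 10000 nM, compound 2 gives 10000 nM, and compound 3 gives 10000 nM.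

From compound 2 to compound 1 the change is methyl in place of carboxy on a saturated chain carbon, three bonds along the chain from an amide-type nitrogen, and the step was no change at the digits printed from compound 2 to compound 1 (within the scatter). Compound 4 `CCCCCCCCNC(=O)C1C(C(=O)O)[C@@H]2CC[C@H]1O2` is not yet measured; it differs from compound 3 by methyl in place of carboxy on a saturated chain carbon, seven bonds along the chain from an amide-type nitrogen. The two starting points themselves differ by 4-carboxybutyl in place of carboxy on a saturated chain carbon, three bonds along the chain from an amide-type nitrogen. The place is not the same: in one case the change sits three bonds along the chain from an amide-type nitrogen, in the other seven bonds along, so this is the same kind of change rather than the same change.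

From compound 3 to compound 4 the expected step is no change at the digits printed from compound 3 to compound 4 (within the scatter), because no change at the digits printed from compound 2 to compound 1 (within the scatter) and no change at the digits printed from compound 1 to compound 3 (within the scatter) show no movement. Compound 4 is estimated at 10000 nM.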

Compound 4, concentration for 50% growth inhibition: 10000 nM
Compound 4: the middle estimate sits on the measured number at the digits printed, within the range that was stated.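

In this assay, putting methyl in place of carboxy seven bonds along the chain from an amide-type nitrogen gives no change at the digits printed from compound 3 to compound 4 (within the scatter), and the other two routes to compound 4 read the same, with no change at the digits printed from compound 2 to compound 4 (within the scatter) and no change at the digits printed from compound 1 to compound 4 (within the scatter). Set beside the earlier step, this change carries over from one core to the other: the same change on two cores in this assay, no change at the digits printed (within the scatter) from compound 2 to compound 1 and no change at the digits printed (within the scatter) from compound 3 to compound 4, 1.0-fold (0.00 log units) apart, within the scatter of two such steps. That agreement is only one of no movement, and it does not show that the change would behave alike in a compound that inhibits growth more strongly.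

Still open, from the compounds shown here alone, is whether any other group on this chain shifts the reading, for instance an amine in place of the carboxy, or a ring in place of the chain.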